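Series notes: side-chain swap from compound 3 to compound 4

This account rests on a few compounds, and the source may have more. Where it says the series, first, only, none or still open, it means among the compounds named here.

Three compounds of the series have numbers in a functional assay on the whole organism (Tail, strain ICR) with Mus musculus as the target, in the tail flick test, with a stated time of 60 min, at a dose of 25 umol/kg by the oral route; a lower number here means a weaker effect, a higher number a stronger effect of the compound at the dose given. Compound 1 `CC[C@H](C)[C@H](NC(=O)CN(c1nc(Cl)nc2[nH]cnc12)C1CC1)C(=O)O` gives 36%; compound 2 `O=C(OCc1ccccc1)[C@@H]1CCCN1C(=O)CN(c1nc(Cl)nc2[nH]cnc12)C1CC1` gives 34.4%; compound 3 `C[C@@H](O)[C@H](NC(=O)CN(c1ncnc2c1ncn2C1CCCCO1)C1CC1)C(=O)OCc1ccccc1` gives 28.4%. These three numbers lie within the usual scatter of one another, so none of them can be set apart. Compound 4 `CC(C)C[C@H](NC(=O)CN(c1ncnc2c1ncn2C1CCCCO1)C1CC1)C(=O)OCc1ccccc1` has not been measured. It differs from compound 3 in one place: isobutyl in place of 1-hydroxyethyl on a saturated chain carbon bound to an amide-type nitrogen and a carbonyl carbon. Within the data shown here, no pair of measured compounds differs in only this way, so the data hold no step to lean on. With nothing pointing in either direction, the expected step stays within the scatter: a number 1.6 percentage points higher from compound 3 to compound 4 (within the scatter). Compound 4 is therefore expected to give about 30% in this assay, within 12% to 50%.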

Compound 4, a percentage reported as activity, at one dose (the size of the read-out at that dose, not a potency): 34.2%
Beside the measured number, compound 4's estimate is 4.2 percentage points below it, and the stated range covers the measured number.
By their numbers in this assay, from the lowest: compounds 3, 4, 2 and 1 (each within the scatter of the next).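

In this assay, among these compounds, the step of a number 5.8 percentage points higher from compound 3 to compound 4 (within the scatter) gives the first reading at this position, on a saturated chain carbon bound to an amide-type nitrogen and a carbonyl carbon. Isobutyl can stand in place of 1-hydroxyethyl, with the hydrogen-bond donor, the hydrogen-bond acceptor and the defined stereocentre of that group gone, and the step stays within the scatter. No evidence on hand bears on this result.

On these data alone, whether an amine or a phenyl ring at this position would stay within the scatter in this assay remains open. As far as these compounds go, it is also open whether a longer chain would do so.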